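Replacing pyridin-2-yl with an indolylmethyl group

The source may hold more compounds than are shown below. What is called first, only, known or untested is meant among the compounds shown, and "the series" means these compounds.

Compound 1 `Cn1c(=O)c(S(=O)(=O)c2ccc(F)cc2F)cc2cnc(Nc3cccc4[nH]ccc34)nc21` gives 1500 nM
Compound 2 `Cn1c(=O)c(S(=O)(=O)c2ccc(F)cc2F)cc2cnc(Nc3ccc4sccc4c3)nc21` gives 500 nM
Compound 3 `Cn1c(=O)c(S(=O)(=O)c2ccc(F)cc2F)cc2cnc(Nc3ccccn3)nc21` gives 35000 nM

In a functional assay on K562 cells (Homo sapiens) for inhibition, read by trypan blue exclusion, with a stated time of 72 h (on this read-out higher numbers stand for weaker inhibition and lower numbers for stronger inhibition), compound 3 holds the highest number of the three, at 35000 nM on this read-out. Compound 4 `Cn1c(=O)c(S(=O)(=O)c2ccc(F)cc2F)cc2cnc(NCc3ccc4[nH]ccc4c3)nc21` differs from it by one change, ((1H-indol-5-yl)methyl in place of pyridin-2-yl on a nitrogen on an aromatic ring), namely (1H-indol-5-yl)methyl in place of pyridin-2-yl on a nitrogen on an aromatic ring. Two large steps bear on this, a 23-fold higher number from compound 1 to compound 3 (1.37 log units; beyond the scatter) and a 70-fold higher number from compound 2 to compound 3 (1.85 log units; beyond the scatter), each ending at pyridin-2-yl. Among the measured compounds shown here, no measured compound carries the entering group, so the range stays wide. A large move to a lower number is expected in this assay, estimated as an 18-fold lower number from compound 3 to compound 4 (1.24 log units; beyond the scatter). For compound 4 the expected value is 2000 nM, with an estimated range from 400 nM to 10000 nM.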

Compound 4, half-maximal inhibitory concentration: 75000 nM
For compound 4 the middle estimate is 38-fold (1.57 log units) below the measured one, and the stated range ends below it.
By their numbers in this assay, from the lowest: compound 2; then compound 1; then compound 3; then compound 4.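

In this assay, (1H-indol-5-yl)methyl on this nitrogen brings no gain over pyridin-2-yl (a 2.1-fold higher number from compound 3 to compound 4 (0.33 log units; beyond the scatter)), and it falls far behind both 1-benzothiophen-5-yl (a 150-fold higher number from compound 2 to compound 4 (2.18 log units; beyond the scatter)) and 1H-indol-4-yl (a 50-fold higher number from compound 1 to compound 4 (1.70 log units; beyond the scatter)). Compound 1 and compound 4 both carry an indole, so an indole alone does not secure the lower number here. Nothing available explains this result.

The compounds shown leave open how the methyl link and the indole attachment point each contribute. A directly attached 1H-indol-5-yl, or a plain benzyl group, would help separate them.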